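This account rests on a few compounds, and the source may have more. Where it says the series, first, only, none or still open, it means among the compounds named here.

Measured so far:
- compound 1, `Cn1cc(-c2ccc(CN3CCC(O)(Cn4cnc5c(-c6ccc(CN)cc6)n(C)nc5c4=O)CC3)c(Cl)c2)cn1`, gives 291 nM
- compound 2, `CCCNCc1ccc(-c2c3ncn(CC4(O)CCN(Cc5ccc(-c6ccco6)cc5Cl)CC4)c(=O)c3nn2C)cc1`, gives 43.9 nM

Both compounds were tested in an assay on isolated protein for inhibition of ubiquitin carboxyl-terminal hydrolase 7 (Homo sapiens), with stated times of 30 min and 2 h; on this read-out lower numbers stand for stronger inhibition and higher numbers for weaker inhibition. Of the two numbers, compound 1 stands at the higher one, which on this read-out means the weaker inhibitor; compound 2 gives the lower number 43.9 nM, and the gap between the two lies beyond the usual scatter of repeated measurements. Compound 2 differs from compound 1 in more than one place, so nothing is known about how any single one of its changes contributes.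

The new compound, compound 3, `Cn1nc2c(=O)n(CC3(O)CCN(Cc4ccc(-c5ccsc5)cc4Cl)CC3)cnc2c1-c1ccc(CN)cc1`, is compound 1 with one change: thiophen-3-yl in place of 1-methyl-1H-pyrazol-4-yl on an aromatic carbon. The shared core, the chloro group and the aminomethyl group are untouched. Among the compounds with values here, no pair of measured compounds shows the effect of this exact change, so the size of the step in this assay is open. Because compound 2 with a different five-membered ring in this place gives 43.9 nM, a modest move to a lower number is expected for compound 3, though the second change in compound 2 leaves this uncertain. The expected step is a 1.8-fold lower number from compound 1 to compound 3 (0.26 log units; within the scatter). For compound 3 the estimated value is 160 nM, with a likely range from 55 nM to 470 nM.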

Compound 3, half-maximal inhibitory concentration: 59.5 nM
For compound 3 the middle estimate is 2.7-fold (0.43 log units) above the measured one, and the stated range covers the measured number.
By their numbers in this assay, from the lowest: compounds 2 and 3 (each within the scatter of the next); then compound 1.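

Within the data shown here, until now, no pair of compounds isolated the aromatic carbon that lies meta to a chloro group and para to a large group, so the effect of this position could not be read on its own. In this assay the change gives a 4.9-fold lower number from compound 1 to compound 3 (0.69 log units; beyond the scatter) with the shared core, the chloro group and the aminomethyl group untouched, so the choice of five-membered aromatic ring at this position alone moves the read-out beyond the usual scatter, towards stronger inhibition. The change replaces 6 heavy atoms and 2 hydrogen-bond acceptors with 5 heavy atoms and 1 hydrogen-bond acceptor, but no measurement here links the shift to either difference or to any other cause.

The compounds shown do not separate the loss of the methyl group from the exchange of ring atoms, which a plain 1H-pyrazol-4-yl group at this position could help to address. They also leave open whether a six-membered ring such as phenyl or pyridin-3-yl would fit this trend, and whether the same step would appear with a propylaminomethyl group in place of the aminomethyl group.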